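This account rests on a few compounds, and the source may have more. Where it says the series, first, only, none or still open, it means among the compounds named here.

Measured values in an ADME assay on HEK293 cells (Homo sapiens) for cytotoxicity, read by MTT assay, with a stated time of 72 h; a lower number here means a stronger inhibitor, a higher number a weaker inhibitor:
- compound 1 `O=C(CN1CCN(C(=O)c2ccc(Br)cc2)CC1)N1CCN(CCCc2c[nH]c3ccccc23)CC1` gives 71900 nM
- compound 2 `O=C(CN1CCN(C(=O)c2cccc(Cl)c2)CC1)N1CCN(CCCc2c[nH]c3ccccc23)CC1` gives 99100 nM

Going by the values given here, compound 1 lies within the usual scatter of compound 2, its only measured neighbour, so the two cannot be ranked. Compound 3 `COc1ccc2[nH]cc(CCCN3CCN(C(=O)CN4CCN(C(=O)c5ccc(Br)cc5)CC4)CC3)c2c1` differs from compound 1 in one place: methoxy in place of hydrogen on an aromatic carbon, which turns 1H-indol-3-yl into 5-methoxy-1H-indol-3-yl (methoxy in place of hydrogen on an aromatic carbon). Among the compounds with values here, the only measured step, a 1.4-fold higher number from compound 1 to compound 2 (0.14 log units; within the scatter), is small, but it changes a different group. No measurement yet tests the methoxy change itself, so the data offer no reason to expect a shift beyond the scatter in this assay, in either direction. The expected change is a 1.0-fold lower number from compound 1 to compound 3 (0.01 log units; within the scatter). The estimated value for compound 3 is 70000 nM, with an expected range from 30000 nM to 150000 nM.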

Compound 3, half-maximal inhibitory concentration: 80500 nM
Compound 3: middle estimate off by 1.2-fold (0.06 log units), on the low side; low and high end bracket the measured number.
By their numbers in this assay, from the lowest: compounds 1, 3 and 2 (each within the scatter of the next).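

Turning 1H-indol-3-yl into 5-methoxy-1H-indol-3-yl in this assay gives a 1.1-fold higher number from compound 1 to compound 3 (0.05 log units; within the scatter), so this first direct test of the change shows no shift that can be told from the scatter. With the 4-bromophenyl group kept in place, methoxy, with its 2 heavy atoms and 1 hydrogen-bond acceptor, can therefore replace hydrogen on this aromatic carbon without a readable change in this assay. Nothing at hand explains this outcome.

Going by these compounds, whether a hydroxyl group or an amine on the same carbon would behave the same way stays open, as does whether methoxy would do so alongside the 3-chlorophenyl group of compound 2. Each of the three numbers also lies within the scatter of the next, so the compounds shown do not reveal which change, if any, could move the number beyond it.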